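The compounds below may be only part of what the source reports. "The series", "measured", "known", "first", "only" and "open" are said of these compounds alone.

In a functional assay on PC-9 cells (Homo sapiens) for inhibition, read by MTT assay, with a stated time of 72 h (on this read-out lower numbers stand for stronger inhibition and higher numbers for weaker inhibition), compound 3 `Cc1cc(Nc2cc(-c3ccccc3)[nH]n2)n2nc(SCc3cccc4ccccc34)nc2n1` gives 3950 nM and compound 1 `Cc1cc(Nc2cc(-c3ccccc3)[nH]n2)n2nc(SCCCc3ccccc3)nc2n1` gives 5030 nM as its value, so the two sit within the scatter of each other. Compound 2 `C#CCSc1nc2nc(C)cc(Nc3cc(-c4ccccc4)[nH]n3)n2n1` gives > 50000 nM as a limit of the assay. Compound 4 `COc1ccc(CSc2nc3nc(C)cc(Nc4cc(-c5ccccc5)[nH]n4)n3n2)cc1` carries 4-methoxyphenyl in place of naphthalen-1-yl on a saturated chain carbon bound to a sulfur. Nearest in kind is naphthalen-1-yl in place of phenethyl, which gave a 1.3-fold lower number from compound 1 to compound 3 (0.10 log units; within the scatter) and stays within the scatter. Only ethynyl stands apart, with an at least 9.9-fold higher number from compound 1 to compound 2 (0.99 log units; beyond the scatter) on entering and an at least 12-fold lower number from compound 2 to compound 3 (1.10 log units; beyond the scatter) on giving way to naphthalen-1-yl. With one six-membered aromatic ring of carbon only remaining, the expected step is a 1.3-fold higher number from compound 3 to compound 4 (0.10 log units; within the scatter) and no more than scatter. Compound 4 is estimated at 5000 nM with an expected range of 2000 nM to 20000 nM for now.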

Compound 4, half-maximal inhibitory concentration: 8110 nM
The estimate for compound 4 lay 1.6-fold (0.21 log units) below the measured number; the range from low to high includes it.
By their numbers in this assay, from the lowest: compounds 3, 1 and 4 (each within the scatter of the next, the first and the last beyond it). At a limit, above all of these: compound 2.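

Among the compounds shown here, on a saturated chain carbon bound to a sulfur, groups carrying an aromatic ring now separate for the first time: 4-methoxyphenyl in place of naphthalen-1-yl gives a 2.1-fold higher number from compound 3 to compound 4 (0.31 log units; beyond the scatter). Against phenethyl, the same group stays inside the scatter, with a 1.6-fold higher number from compound 1 to compound 4 (0.21 log units; within the scatter). Compound 2 stands at a limit, so the change from ethynyl to 4-methoxyphenyl reads only as a bound, with an at least 6.1-fold lower number from compound 2 to compound 4 (0.78 log units; beyond the scatter).

From the compounds shown here alone, whether the loss of the second ring or the entry of the methoxy oxygen drives the change from naphthalen-1-yl stays open; plain phenyl or 4-chlorophenyl at this place would divide the two. Going by these compounds, how an amine or a carboxylic acid on this chain would read also stays open.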